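The source may report more compounds than this note shows. Statements on the series, on what has been measured and on what is new or still open speak of the compounds shown alone.

Measured so far in a functional assay on COLO 205 cells (Homo sapiens) for inhibition, read by sulforhodamine B assay (a higher number here means a weaker inhibitor of growth, a lower number a stronger inhibitor of growth), for this series:
- compound 1 `Cc1ccc2[nH]c(-c3ccc(-c4ccc(-c5ccc(N(C)C)cc5)cc4)cc3)nc2c1` gives 9210 nM
- compound 2 `Cc1ccc2[nH]c(-c3ccc(-c4ccc(-c5cccc(Cl)c5)cc4)cc3)nc2c1` gives 2780 nM
- compound 3 `COc1ccc(-c2ccc(-c3ccc(-c4nc5cc(C)ccc5[nH]4)cc3)cc2)cc1OC` gives 2320 nM

Compound 3 stands at the low end of these numbers, but it shares that end with its nearest neighbour: a 1.2-fold lower number from compound 2 to compound 3 (0.08 log units; within the scatter) stays within the scatter, while a 4.0-fold lower number from compound 1 to compound 3 (0.60 log units; beyond the scatter) lies beyond it.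

The next entry is compound 4 `COc1cc(-c2ccc(-c3ccc(-c4nc5cc(C)ccc5[nH]4)cc3)cc2)cc(OC)c1OC`, which carries methoxy in place of hydrogen on an aromatic carbon. This is methoxy in place of hydrogen on an aromatic carbon, ortho to a methoxy group, meta to a second methoxy group and meta to a large group.

Among the measured compounds shown here, no measured step adds a methoxy group alone, so the evidence is indirect. The three measured steps each replace one substituted phenyl group with another. The two that leave the 4-(dimethylamino)phenyl compound are modest, a 3.3-fold lower number from compound 1 to compound 2 (0.52 log units; beyond the scatter) and the step to compound 3 already given. For the measured compounds named here, the one closest to this change, from 3-chlorophenyl to 3,4-dimethoxyphenyl, is a 1.2-fold lower number from compound 2 to compound 3 (0.08 log units; within the scatter) and did not move the number beyond the scatter.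

The step expected in this assay is therefore small, with none beyond the scatter: a 1.2-fold lower number from compound 3 to compound 4 (0.06 log units; within the scatter) is the expected step.

For compound 4 the estimate is 2000 nM, with an expected range from 800 nM to 5000 nM.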

Compound 4, concentration for 50% growth inhibition: 190 nM
Compound 4: the middle estimate sits 11-fold (1.02 log units) above what was measured, and the stated range ends above it.
By their numbers in this assay, from the lowest: compound 4; then compounds 3 and 2 (each within the scatter of the next); then compound 1.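

This position, on an aromatic carbon ortho to a methoxy group, meta to a second methoxy group and meta to a large group, proves sensitive in this assay: methoxy in place of hydrogen gives a 12-fold lower number from compound 3 to compound 4 (1.09 log units; beyond the scatter). The earlier steps shown here exchanged one whole substituted phenyl group for another and stayed smaller, the largest being a 4.0-fold lower number from compound 1 to compound 3 (0.60 log units; beyond the scatter), while a 1.2-fold lower number from compound 2 to compound 3 (0.08 log units; within the scatter) did not leave the scatter, so the addition of 2 heavy atoms here moved the number further than any of those exchanges. No measurement at hand bears on why this single change has so large an effect.

The compounds shown leave open whether methoxy itself is needed at this position, or whether a hydroxyl, an ethoxy group, fluorine or an amine would give a step of similar size. Also open, going by these compounds, is whether the step depends on the other two methoxy groups staying in place, or whether methoxy at this position would act the same way on the 3-chlorophenyl compound.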